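Replacing the ethoxyphenyl amide in an adenosine-receptor series

A few compounds are considered here, and "the series" means these few. Any claim that something is new, unique, unknown or untested is made for them only; others in the source may bear on it.

Compound 1 `CCOc1ccccc1C(=O)Nc1nc(-c2ccccc2)nc2c1nnn2Cc1ccccc1`: 1850 nM
Compound 2 `O=C(Nc1nc(-c2ccccc2)nc2c1nnn2Cc1ccccc1)c1cccc([N+](=O)[O-])c1`: 77 nM
Compound 3 `O=C(Nc1nc(-c2ccccc2)nc2c1nnn2Cc1ccccc1)C1CCCC1`: 2.5 nM

Three amides sharing one core have been measured in an assay (strain Wistar) for displacement of a labelled ligand from adenosine receptor A1 (Rattus norvegicus), read by scintillation counting; on this read-out lower numbers stand for stronger inhibition and higher numbers for weaker inhibition. Compound 1 stands at the top of the three numbers, the weakest binder measured: the nearest is compound 2, reached by a 24-fold lower number from compound 1 to compound 2 (1.38 log units; beyond the scatter), and the furthest is compound 3, reached by a 740-fold lower number from compound 1 to compound 3 (2.87 log units; beyond the scatter). The step between the other two, a 31-fold lower number from compound 2 to compound 3 (1.49 log units; beyond the scatter), is also large.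

Compound 4 `O=C(Nc1nc(-c2ccccc2)nc2c1nnn2Cc1ccccc1)c1ccc(C(F)(F)F)cc1` is not yet measured. It differs from compound 1 in one place: 4-(trifluoromethyl)phenyl in place of 2-ethoxyphenyl on a carbonyl carbon.

For the measured compounds named here, two measured steps bear on this change, both starting from compound 1 and both exchanging the group on the carbonyl carbon. The closer analogy is a 24-fold lower number from compound 1 to compound 2 (1.38 log units; beyond the scatter), where one substituted phenyl replaced another; a 740-fold lower number from compound 1 to compound 3 (2.87 log units; beyond the scatter) shows that a non-aromatic ring goes further still. Since compound 4 keeps an aromatic ring, the step from compound 1 is expected to be large and downward in this assay, and of roughly the size seen for compound 2: a 19-fold lower number from compound 1 to compound 4 (1.27 log units; beyond the scatter). Compound 4 is therefore estimated at 100 nM, within a range of 25 nM to 400 nM.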

Compound 4, inhibition constant: 123 nM
Compound 4: the middle estimate sits 1.2-fold (0.09 log units) below what was measured; measured number inside the range.
By their numbers in this assay, from the lowest: compound 3; then compounds 2 and 4 (each within the scatter of the next); then compound 1.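

In this assay, a second substituted phenyl group also lies far below the 2-ethoxyphenyl amide, a 15-fold lower number from compound 1 to compound 4 (1.18 log units; beyond the scatter), so compound 2 is no longer the only aromatic replacement to do so. Compound 2 and compound 4 cannot be told apart, a 1.6-fold higher number from compound 2 to compound 4 (0.20 log units; within the scatter), even though 3-nitrophenyl and 4-(trifluoromethyl)phenyl are different groups, so on the carbonyl carbon these two aromatic groups give values within the scatter of each other. The gap to the cyclopentyl amide remains wide for the new group, a 49-fold higher number from compound 3 to compound 4 (1.69 log units; beyond the scatter), leaving all three substituted phenyl amides shown well above compound 3, and no measurement given here accounts for any of these steps.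

The compounds shown leave open whether the high number of compound 1 belongs to the ethoxy group or to the 2-ethoxyphenyl group as a whole, a question that a plain phenyl or a 4-ethoxyphenyl on the carbonyl carbon would address. They also leave open whether the low number of compound 3 is particular to cyclopentyl or would carry over to a cyclohexyl ring or an open butyl chain.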